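The source may report more compounds than this note shows. Statements on the series, on what has been measured and on what is new or still open speak of the compounds shown alone.

Among the compounds with values here, in a functional assay on L1210 cells (Mus musculus) for cytotoxicity, read by MTT assay, with a stated time of 72 h (a lower number here means a stronger inhibitor, a higher number a weaker inhibitor), compound 1 (`CCCCCCCCCCCC(=O)c1cc(O)c(O)c(O)c1`) gives 8120 nM, and compound 2 (`CCCCCCCCCCCCC(=O)c1cc(O)c(O)c(O)c1`) gives 21000 nM, the higher of the two numbers so far and therefore the weaker result. Compound 3 (`CCCCCCCCCCCCCCC(=O)c1cc(O)c(O)c(O)c1`) differs from compound 2 by ethyl in place of hydrogen on a saturated chain carbon, ten or more bonds along the chain from a carbonyl carbon. Within the data shown here, only one measured step bears on this change: a 2.6-fold higher number from compound 1 to compound 2 (0.41 log units; beyond the scatter), with methyl in place of hydrogen at the same kind of place. That step is modest but beyond the scatter. A single step is thin support, and the trend may not hold for a larger addition. Even so, a further rise of similar or somewhat larger size is expected in this assay. The expected change is a 2.4-fold higher number from compound 2 to compound 3 (0.38 log units; beyond the scatter). For compound 3 the estimated value is 50000 nM, with an expected range of 16000 nM to 150000 nM.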

Compound 3, half-maximal inhibitory concentration: 12500 nM
Beside the measured number, compound 3's estimate is 4.0-fold (0.60 log units) above it; measured number outside the range, below it.
By their numbers in this assay, from the lowest: compounds 1, 3 and 2 (each within the scatter of the next, the first and the last beyond it).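

In this assay ethyl in place of hydrogen on a saturated chain carbon, ten or more bonds along the chain from a carbonyl carbon, gives a 1.7-fold lower number from compound 2 to compound 3 (0.23 log units; within the scatter) so the rise seen with methyl at this place does not carry over to the larger addition. Propyl in place of hydrogen at the same place gives a 1.5-fold higher number from compound 1 to compound 3 (0.19 log units; within the scatter) and so, of the three compounds, only compound 1 and compound 2 stand apart beyond the scatter, with compound 3 going against any steady climb with chain length. Nothing available here accounts for this result.

The compounds shown leave open whether a longer chain than that of compound 3 would stay within the scatter of these numbers. They also leave open what an amine or a carboxylic acid on this chain would do.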